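This account rests on a few compounds, and the source may have more. Where it says the series, first, only, none or still open, it means among the compounds named here.

The shared core of compound 1, `CC(=O)Nc1nn(-c2ccccc2)c(=O)c2ccccc12`, carries a small acetyl group on the amide nitrogen. In an assay on CHO cells for displacement of a labelled ligand from adenosine receptor A1 (Homo sapiens), tested at 10 uM (a lower number here means less inhibition, a higher number more inhibition at the concentration tested (going by the name of the read-out)), compound 1 gives 52%. Compound 2, `O=C(Nc1nn(-c2ccccc2)c(=O)c2ccccc12)c1ccccc1`, replaces that methyl with a phenyl; in this assay compound 2 gives 44%, a shift of a number 8 percentage points lower from compound 1 to compound 2 (within the scatter). Compound 3, `COc1ccc(C(=O)Nc2nn(-c3ccccc3)c(=O)c3ccccc23)cc1`, adds a methoxy group to that phenyl, and in this assay compound 3 gives 0%, the lowest of the three numbers; the step from compound 2 was a number 44 percentage points lower from compound 2 to compound 3 (beyond the scatter), and from compound 1 it was a number 52 percentage points lower from compound 1 to compound 3 (beyond the scatter).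

Compound 4, `O=C(NCc1ccccc1)Nc1nn(-c2ccccc2)c(=O)c2ccccc12`, differs from compound 3 by benzylamino in place of 4-methoxyphenyl on a carbonyl carbon. The two large drops onto compound 3 both bear on this position, and the loss of the methoxy-bearing group is the reversal of the change that erased inhibition. For the measured compounds named here, no measured compound carries a benzylamino here, so the expectation is loose. A return toward the region of compound 1 and compound 2 is expected, a step of a number 30 percentage points higher from compound 3 to compound 4 (beyond the scatter) upward. Compound 4 is estimated at 30%, between 5% and 55%.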

Compound 4, a percentage reported as inhibition, at one concentration (the size of the read-out at that concentration, not a potency): 20%
The estimate for compound 4 lay 10 percentage points above the measured number; the range from low to high includes it.
By their numbers in this assay, from the lowest: compound 3; then compound 4; then compounds 2 and 1 (each within the scatter of the next).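

Benzylamino and 4-methoxyphenyl have the same count of heavy atoms and each holds one six-membered aromatic ring, yet in this assay the change gives a number 20 percentage points higher from compound 3 to compound 4 (beyond the scatter), so an equal heavy-atom count does not by itself fix the number at this carbonyl carbon. The recovery is only partial, with a number 24 percentage points lower from compound 2 to compound 4 (beyond the scatter) and a number 32 percentage points lower from compound 1 to compound 4 (beyond the scatter), so benzylamino does not return the number to the level seen with phenyl or methyl. No measurement here explains these shifts.

The compounds shown leave open how a simple amino group or a longer chain such as phenethylamino would behave on this carbonyl carbon. They also leave open what a methoxy group on the ring of the benzylamino would do, a test of whether the drop at compound 3 carries over to this group.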